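The source may hold more compounds than are shown below. What is called first, only, known or untested is meant among the compounds shown, and "the series" means these compounds.

Measured in a functional assay on the whole organism with Mus musculus as the target, with a stated time of 0.5 h; on this read-out higher numbers stand for an effect only at larger amounts of compound and lower numbers for an effect already at smaller amounts:
- Compound 1 `O=C1O[C@]2(c3ccccc3)CCCCCN1C2=O`: < 400 mg/kg, a limit
- Compound 2 `O=C1O[C@@]2(c3ccccc3)CCCCCN1C2=O`: 50 mg/kg

Going by the values given here, compound 2, at 50 mg/kg, holds the only actual number in this assay. Compound 3 `O=C1OC2(c3ccccc3)CCCCCN1C2=O` differs from it in one way: the two compounds have the same atoms and bonds; at least one stereo element is drawn with a configuration in one of them and without one in the other: 1 of 1 stereo elements differ; a stereocentre at a saturated ring carbon is drawn R in compound 2 and without a configuration in compound 3. Among the compounds with values here, the only measured step bearing on this is a step that the limit leaves unreadable from compound 1 to compound 2, and it offers no size to carry over because of the limit of < 400 mg/kg in this assay, at which 1 of the 2 values shown sits. No step beyond the scatter is therefore expected in this assay, and no firm direction can be given. The expected step is a 1.4-fold higher number from compound 2 to compound 3 (0.15 log units; within the scatter). Compound 3 is estimated at 70 mg/kg, with an expected range of 30 mg/kg to 170 mg/kg.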

Compound 3, dose for half-maximal effect: 45 mg/kg
Estimate against measurement, compound 3: 1.6-fold (0.19 log units) above; low and high end bracket the measured number.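

In this assay, going by these compounds alone, the first readable step at this stereocentre is a 1.1-fold lower number from compound 2 to compound 3 (0.05 log units; within the scatter). Within the data shown here, the only difference behind that step is this: the fact that one of compounds 2 and 3 is drawn with a defined configuration and the other without, at the place where they differ Compound 1 carries < 400 mg/kg, a limit, so the steps from it cannot be read.

From the compounds shown here alone, it therefore stays open whether the configuration drawn S differs from the one drawn R at this stereocentre. How a methoxy group or an amine on the shared core would shift the dose is also left open.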